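Swapping the Thiophene Ring on a Shared Core

This account rests on a few compounds, and the source may have more. Where it says the series, first, only, none or still open, it means among the compounds named here.

Of the compounds shown here, three have been measured in a functional assay for inhibition, with Homo sapiens as the target; on this read-out higher numbers stand for weaker inhibition and lower numbers for stronger inhibition. Compound 1 `Cc1ccsc1-c1ccnc(Nc2ccc(N(C)C)cc2)n1` gives 1800 nM in this assay. Compound 2 `CN(C)c1cccc(Nc2nccc(-c3cccs3)n2)c1` gives 2400 nM in this assay, and compound 3 `c1cc(Nc2nccc(-c3cccs3)n2)cc(OCCn2ccnc2)c1` gives 100 nM in this assay. Among these three numbers compound 1 stands second highest; its value and that of compound 2 lie within the usual scatter of each other, while compound 3 sits far lower, beyond the scatter. Within the data shown here, the only step between measured compounds that differ in a single place is a 24-fold lower number from compound 2 to compound 3 (1.38 log units; beyond the scatter), and that change sits on the ring carrying the amine, not on the thiophene.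

Compound 4 `CN(C)c1ccc(Nc2nccc(-c3ccsc3)n2)cc1` has not yet been measured. It differs from compound 1 by thiophen-3-yl in place of 3-methylthiophen-2-yl on an aromatic carbon. Among the measured compounds shown here, no measured pair differs in this place, so the step from compound 2 to compound 3 gives no direct guide to what the thiophene swap will do. With nothing in the measured numbers pointing either way, a step within the scatter is expected: no change at the digits printed from compound 1 to compound 4 (within the scatter). Compound 4 is therefore estimated to give about 1800 nM in this assay, with a range from 500 nM to 6000 nM.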

Compound 4, half-maximal inhibitory concentration: 2100 nM
Beside the measured number, compound 4's estimate is 1.2-fold (0.07 log units) below it; the range from low to high includes it.
By their numbers in this assay, from the lowest: compound 3; then compounds 1, 4 and 2 (each within the scatter of the next).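

In this assay, among these compounds, the change at this place reads as a 1.2-fold higher number from compound 1 to compound 4 (0.07 log units; within the scatter) and this is the first reading of any change to the thiophene on the shared core, since the earlier step lay on the ring carrying the amine. The swap does two things at once: the methyl group leaves, and the sulfur ring is attached through a different carbon, yet compound 4 stays within the scatter of compound 1, so this place on the ring with two nitrogens accepts both thiophene forms without a clear shift in the number. No measurement given here explains this result.

As far as these compounds go, whether the loss of the methyl group and the new point of attachment each leave the number alone, or instead offset one another, stays open, and a plain thiophen-2-yl group on the core of compound 1 would separate the two. Also open, from the compounds shown here alone, is how this place would respond to something less like thiophene, such as a phenyl ring, a pyridine ring or a ring bearing a carboxylic acid.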